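Aryl variation on the aromatic nitrogen: cytotoxicity notes

A few compounds are considered here, and "the series" means these few. Any claim that something is new, unique, unknown or untested is made for them only; others in the source may bear on it.

Measured in an ADME assay on HepG2 cells (Homo sapiens) for cytotoxicity, read by MTT assay, with a stated time of 24 h; on this read-out lower numbers stand for higher toxicity in this test and higher numbers for lower toxicity in this test:
compound 1 `CC(C)=CCC1=C(OCc2cn(Cc3ccccc3)nn2)C(=O)c2ccccc2C1=O` gives 414000 nM.
compound 2 `CC(C)=CCC1=C(OCc2cn(-c3cccnc3)nn2)C(=O)c2ccccc2C1=O` gives 1030000 nM.
compound 3 `CC(C)=CCC1=C(OCc2cn(-c3ccc(S(N)(=O)=O)cc3)nn2)C(=O)c2ccccc2C1=O` gives 483000 nM.

In this assay compound 3 holds the second highest of the three numbers; its number and that of compound 1 lie within the scatter of each other, while compound 2 sits apart, as the step of a 2.1-fold lower number from compound 2 to compound 3 (0.33 log units; beyond the scatter) shows. The remaining steps are a 2.5-fold higher number from compound 1 to compound 2 (0.40 log units; beyond the scatter) and a 1.2-fold higher number from compound 1 to compound 3 (0.07 log units; within the scatter). Compound 4 `CC(C)=CCC1=C(OCc2cn(-c3ccc([N+](=O)[O-])cc3)nn2)C(=O)c2ccccc2C1=O` differs from compound 3 by nitro in place of sulfamoyl on an aromatic carbon. Going by the values given here, no measured step exchanges one substituent on this phenyl ring for another; the closest comparisons are the three swaps of the whole group on the aromatic nitrogen, and each of those moved the number by at most a modest amount. The step expected in this assay is therefore a 1.1-fold lower number from compound 3 to compound 4 (0.03 log units; within the scatter), nothing beyond the scatter. For compound 4 the estimated number in this assay is 450000 nM, with a range from 200000 nM to 1000000 nM.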

Compound 4, half-maximal cytotoxic concentration: 540000 nM
Compound 4: middle estimate off by 1.2-fold (0.08 log units), on the low side; the range from low to high includes it.
By their numbers in this assay, from the lowest: compounds 1, 3, 4 and 2 (each within the scatter of the next, the first and the last beyond it).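

Sulfamoyl and nitro, at the same place para to a large group, give the first direct substituent exchange on this phenyl ring in this assay, and the read-out does not separate them (a 1.1-fold higher number from compound 3 to compound 4 (0.05 log units; within the scatter)). Compound 4 also lies within the scatter of both ends of the set (a 1.9-fold lower number from compound 2 to compound 4 (0.28 log units; within the scatter); a 1.3-fold higher number from compound 1 to compound 4 (0.12 log units; within the scatter)), even though compound 1 and compound 2 lie beyond the scatter of each other, so the 4-nitrophenyl group cannot be placed with either end. Nothing available gives a cause for this result.

Still open, on these data alone, is whether an amine or a carboxylic acid at this place would stay within the same band in this assay. Also open, as far as these compounds go, is whether a longer chain between the aromatic nitrogen and the phenyl ring would leave the number where compound 1 has it.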